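The compounds below may be only part of what the source reports. "The series", "measured", "known", "first", "only" and "open" are said of these compounds alone.

Three compounds have been measured in an ADME assay on J774 cells (Mus musculus) for cytotoxicity, read by MTT assay, with a stated time of 48 h, tested at 150 ug/mL; a higher number here means a weaker effect of the compound at the concentration tested, a lower number a stronger effect:

Compound 1 `O=C(N/N=C/c1ccc(Br)cc1)c1cnccn1`: 94%
Compound 2 `COc1ccc(/C=N/NC(=O)c2cnccn2)cc1`: 55%
Compound 3 `N#Cc1ccccc1/C=N/NC(=O)c1cnccn1`: 70%

Compound 2 stands at the lowest of these three numbers, so it has the strongest effect on the cells seen so far: compound 3 is nearer, and compound 1 furthest away, both beyond the scatter. Among the measured compounds shown here, the only step between two measured compounds that differ in one place is a number 39 percentage points lower from compound 1 to compound 2 (beyond the scatter), which shows that a change at this one spot on the ring can move the number a great deal.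

Compound 4 `CN(C)c1ccc(/C=N/NC(=O)c2cnccn2)cc1` differs from compound 2 in the same place: dimethylamino in place of methoxy on an aromatic carbon. For the measured compounds named here, no measured step swaps methoxy for dimethylamino, so the earlier step says only that this spot matters, not in which direction the new group will move the number. The estimate therefore stays close to compound 2 with a wide margin on either side. Compound 4 is expected to give about 52%, between 25% and 82%, a step of a number 3 percentage points lower from compound 2 to compound 4 (within the scatter) that is expected to be within the scatter.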

Compound 4, a percentage reported as activity, at one concentration (the size of the read-out at that concentration, not a potency): 89%
Estimate against measurement, compound 4: 37 percentage points below; the measured number lies above the stated range.
By their numbers in this assay, from the lowest: compound 2; then compound 3; then compounds 4 and 1 (each within the scatter of the next).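

In this assay the swap of methoxy for dimethylamino gives a number 34 percentage points higher from compound 2 to compound 4 (beyond the scatter) on this aromatic carbon, so the number can move a long way even when the two groups have the same counts of hydrogen-bond donors and acceptors. Dimethylamino and bromo, by contrast, are separated only by a number 5 percentage points lower from compound 1 to compound 4 (within the scatter) and so cannot be told apart here, which leaves methoxy alone among these three groups in giving the clearly lower number. Nothing measured on these compounds accounts for why methoxy stands apart.

Still open, from the compounds shown here alone, is whether this low number is particular to methoxy or is shared by close relatives such as ethoxy or a free hydroxyl. A primary amine in the same place would show whether compound 4 keeps its number once the two methyl groups are gone.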